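Removing the Methoxy Group from Compound 3

This account rests on a few compounds, and the source may have more. Where it says the series, first, only, none or still open, it means among the compounds named here.

Compound 1 `Fc1ccc(/C=C/c2cc3ccccc3nc2Cl)cc1`, compound 2 `COc1ccc2nc(Cl)c(/C=C/c3ccc(F)cc3)cc2c1` and compound 3 `COc1ccc2nc(Cl)c(/C=C\c3cc(C(F)(F)F)cc(C(F)(F)F)c3)cc2c1` have been tested in a functional assay on HeLa cells (Homo sapiens) for antiproliferative activity, read by sulforhodamine B assay, with a stated time of 72 h (a lower number here means a stronger inhibitor, a higher number a weaker inhibitor), while compound 4 `FC(F)(F)c1cc(/C=C\c2cc3ccccc3nc2Cl)cc(C(F)(F)F)c1` has not. In this assay compound 1 gives only a limit, > 50000 nM. Compound 2 likewise gives only a limit, > 50000 nM. Going by the values given here, compound 3 gives 4140 nM, the only plain number among the three measured compounds; the difference between the core of compound 3 and the core of compound 2 is not broken down here. The step that the two limits leave unreadable from compound 2 to compound 1, (hydrogen in place of methoxy on an aromatic carbon), cannot be read because both of its ends sit at the limit of > 50000 nM in this assay, at which 2 of the 3 values shown sit. The same change, (hydrogen in place of methoxy on an aromatic carbon), leads from compound 3 to compound 4. Since the measured step gives no readable size, the expectation for compound 4 rests on compound 3 and its value 4140 nM, with room for a modest shift in either direction. The expected step of a 1.9-fold higher number from compound 3 to compound 4 (0.29 log units; within the scatter) is estimated as a small weakening. Compound 4 is therefore estimated to give 8000 nM, with a range from 2500 nM to 30000 nM.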

Compound 4, half-maximal inhibitory concentration: 6780 nM
Compound 4: middle estimate off by 1.2-fold (0.07 log units), on the high side; measured number inside the range.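

In this assay, hydrogen in place of methoxy on an aromatic carbon gives a 1.6-fold higher number from compound 3 to compound 4 (0.21 log units; within the scatter), so in this one pair the change shows no effect that can be told apart from the usual scatter of repeated measurements. The same change cannot be read in the other pair, from compound 2 to compound 1, since both of its ends are limits and not numbers: the limit of > 50000 nM in this assay, at which 2 of the 4 values shown sit. The series therefore offers one readable step and nothing to set beside it, so this result shows neither that the change carries over from one core to another nor that it fails to, and the two pairs also differ elsewhere in their structures.

The compounds shown leave open what a group other than methoxy or hydrogen would do on that aromatic carbon, for example an amine, a carboxylic acid or a longer chain such as ethoxy. They also leave open whether the step would keep its size in a second pair with plain numbers at both ends.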